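The source may report more compounds than this note shows. Statements on the series, on what has been measured and on what is new or still open speak of the compounds shown alone.

Measured compounds in a toxicity assay on NIH3T3 cells (Mus musculus) for cytotoxicity, read by resazurin assay; on this read-out lower numbers stand for an effect already at smaller amounts and higher numbers for an effect only at larger amounts of compound:

Compound 1, `O=C(c1ccc(NCc2cncn2Cc2ccc(-c3ccccc3)cc2)cc1-c1ccccc1)N1CCCCC1`, gives > 1000 nM, a limit of the assay rather than a number.
Compound 2, `COC(=O)c1ccc(NCc2cncn2Cc2cccc(C)c2)cc1-c1ccccc1`, gives > 10000 nM, again only a limit.
Compound 3, `CN(C)C(=O)c1ccc(NCc2cncn2Cc2ccc(-c3ccccc3)cc2)cc1-c1ccccc1`, gives > 1000 nM, also a limit.

Compound 2 thus stands at the limit of > 10000 nM in this assay, at which 1 of the 3 values shown sits, the only one of the three at that position; the other two sit at the limit of > 1000 nM in this assay, at which 2 of the 3 values shown sit. No value in the set is a number, so no ordering among the three can be read.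

For the measured compounds named here, the single step between measured compounds, a step that the two limits leave unreadable from compound 1 to compound 3, concerns the group on the carbonyl carbon and is unreadable from its two limits. It does not touch the part of the molecule that changes on the way to compound 4, `COC(=O)c1ccc(NCc2cncn2Cc2ccc(F)cc2F)cc1-c1ccccc1`. That change is 2,4-difluorophenyl in place of 3-methylphenyl on a saturated chain carbon bound to an aromatic nitrogen. Going by the values given here, no measured step bears on this position, so there is no direct evidence for its effect in this assay.

Given that compound 2 sits at a limit and every measured value is a limit, compound 4 is expected to show no step beyond the scatter, a number no higher from compound 2 to compound 4 (the limit leaves the size open), and is estimated at 10000 nM, within 3000 nM to 30000 nM.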

Compound 4, half-maximal effective concentration: > 1000 nM
Compound 4: a limit, no number; the forecaster's own chance of this, stated with the estimate: 70%; the middle value does not contradict the limit.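

For the compounds shown here, compound 2 and compound 4 both give only limits, not numbers, so no step between them can be read. The compounds shown leave open what 2,4-difluorophenyl in place of 3-methylphenyl does in this assay, since no compound here has a measured number.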